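Replacing a trifluoromethylphenyl urea end with difluorophenyl

The compounds below may be only part of what the source reports. "The series", "measured", "known", "first", "only" and "open" are said of these compounds alone.

Compound 1 `CN(C)CCn1cnnc1-c1cc(Oc2ccc(NC(=O)Nc3ccc(Cl)c(C(F)(F)F)c3)cc2F)ccn1` is the reference point here: in a functional assay on NCI-H460 cells (Homo sapiens) for antiproliferative activity, read by MTT assay, with a stated time of 72 h (a lower number here means a stronger inhibitor, a higher number a weaker inhibitor), compound 1 gives 1150 nM. Compound 2 `CN(C)CCn1cnnc1-c1cc(Oc2ccc(NC(=O)Nc3ccccc3C(F)(F)F)cc2F)ccn1` differs from it only at the aryl group attached to the urea nitrogen. For compound 2 the read-out reached only a limit of the assay, > 50000 nM. The change an at least 43-fold higher number from compound 1 to compound 2 (1.63 log units; beyond the scatter) therefore cannot be measured exactly, and the limit of > 50000 nM in this assay, at which 1 of the 2 values shown sits, is the reason compound 2 stands only at a boundary rather than at a number.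

Compound 3 `CN(C)CCn1cnnc1-c1cc(Oc2ccc(NC(=O)Nc3ccc(F)c(F)c3)cc2F)ccn1` takes the next step from compound 2: 3,4-difluorophenyl in place of 2-(trifluoromethyl)phenyl on an amide-type nitrogen. Going by the values given here, the one measured step bearing on this position shows that the aryl group on the urea nitrogen matters greatly, and compound 1 with its halogenated ring sits far stronger than compound 2. Compound 3 also carries halogens on its ring, so compound 3 is expected to return to a measurable number, estimated at 5000 nM with a range of 1000 nM to 40000 nM, meaning an expected step of an at least 10-fold lower number from compound 2 to compound 3 (1.00 log units; beyond the scatter).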

Compound 3, half-maximal inhibitory concentration: 9050 nM
For compound 3 the middle estimate is 1.8-fold (0.26 log units) below the measured one; low and high end bracket the measured number.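

Compound 3 shows that the aryl group on the urea nitrogen does not need a trifluoromethyl group to give a measurable number in this assay, with an at least 5.5-fold lower number from compound 2 to compound 3 (0.74 log units; beyond the scatter) on this change. The 3,4-difluorophenyl ring still recovers only part of the strength, leaving a 7.9-fold higher number from compound 1 to compound 3 (0.90 log units; beyond the scatter) and keeping compound 1 the strongest of the three. For compound 2 the value > 50000 nM is a limit and not a number, so the first of these steps gives only a bound: the limit of > 50000 nM in this assay, at which 1 of the 3 values shown sits.

On these data alone, what remains open is whether the chlorine or the trifluoromethyl group of compound 1 counts for more at this position. Also open, as far as these compounds go, is where an unsubstituted phenyl ring, or a phenyl ring carrying a methoxy group or a nitrile, would fall in this order.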